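Furan to thiophene swap across two cores

This account rests on a few compounds, and the source may have more. Where it says the series, first, only, none or still open, it means among the compounds named here.

Compound 1 `CC(C)OC(=O)C1=C(C(F)(F)F)NC(=O)NC1c1ccco1` gives 11% in an assay on cells for displacement of a labelled ligand from adenosine receptor A1 (Homo sapiens), read by radioligand binding, with a stated time of 60 min, tested at 1 uM; on this read-out lower numbers stand for less inhibition and higher numbers for more inhibition at the one concentration tested (going by the name of the read-out). Compound 3 `CC1=C(C(=O)OCC(F)(F)F)C(c2ccco2)NC(=O)N1` gives 10% in this assay, and compound 2 `CC1=C(C(=O)OCC(F)(F)F)C(c2cccs2)NC(=O)N1` gives 3%. The change thiophen-2-yl in place of furan-2-yl on a saturated ring carbon produced a number 7 percentage points lower from compound 3 to compound 2 (within the scatter). Compound 4 `CC(C)OC(=O)C1=C(C(F)(F)F)NC(=O)NC1c1cccs1` is not yet measured; it carries thiophen-2-yl in place of furan-2-yl on a saturated ring carbon. The difference between the two cores of compound 1 and compound 3 is not broken down here. The place of the change differs: in compound 1 it is next to the ring atom that bears an isopropoxycarbonyl group (6 heavy atoms) and two ring bonds from the ring atom that bears a trifluoromethyl group (4 heavy atoms), whereas in compound 3 it is next to the ring atom that bears a group of 8 heavy atoms and two ring bonds from the ring atom that bears a methyl group (1 heavy atom), so it is the same kind of change, not the same. Beside the earlier step, a step of a number 5 percentage points lower from compound 1 to compound 4 (within the scatter) is expected, because a number 7 percentage points lower from compound 3 to compound 2 (within the scatter) stayed within the scatter. Compound 4 is estimated at 6%, between -5% and 16%.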

Compound 4, a percentage reported as inhibition, at one concentration (the size of the read-out at that concentration, not a potency): 8%
Compound 4: the middle estimate sits 2 percentage points below what was measured; the measured number falls inside the stated range.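

Thiophen-2-yl in place of furan-2-yl on a saturated ring carbon gives a number 3 percentage points lower from compound 1 to compound 4 (within the scatter) in this assay. Set beside the earlier step, the change reads the same on the two cores: the same change on two cores in this assay, a number 7 percentage points lower (within the scatter) from compound 3 to compound 2 and a number 3 percentage points lower (within the scatter) from compound 1 to compound 4, 4 percentage points apart, within the scatter of two such steps This shows only that neither core gives a step beyond the scatter; it does not show a real effect of the change that carries over, nor how the change would behave on a core where the number moves more.

The compounds shown leave open whether an amine or a carboxylic acid in place of the furan-2-yl or thiophen-2-yl would give a step beyond the scatter. As far as these compounds go, the effect of a longer chain in place of the isopropoxycarbonyl group also remains open.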